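Morpholin-4-yl on the carbonyl carbon: expected step

This account rests on a few compounds, and the source may have more. Where it says the series, first, only, none or still open, it means among the compounds named here.

In a functional assay with Oryctolagus cuniculus as the target (on this read-out lower numbers stand for stronger inhibition and higher numbers for weaker inhibition), compound 1 `COc1ccc(-c2nc(CN(C)C)sc2-c2ccc(OC)cc2)cc1` gives 96 nM. Compound 3 `COc1ccc(-c2nc(CNC(=O)C3=NNC(=O)CC3)sc2-c2ccc(OC)cc2)cc1` gives 55 nM. Compound 2 `COc1ccc(-c2nc(CNC(=O)CSC)sc2-c2ccc(OC)cc2)cc1` reads < 100 nM, and this is a limit, not a number. Among the measured compounds shown here, compound 3 and compound 1 therefore carry the only two numbers, and these lie within the scatter of each other.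

Compound 4 `COc1ccc(-c2nc(CNC(=O)N3CCOCC3)sc2-c2ccc(OC)cc2)cc1` keeps the shared core and the carbonyl, with the change (a group of 6 heavy atoms (4 carbon, 1 nitrogen, 1 oxygen; one six-membered non-aromatic ring with 2 hetero atoms) in place of a group of 7 heavy atoms (4 carbon, 2 nitrogen, 1 oxygen; one six-membered non-aromatic ring with 2 hetero atoms), on a carbonyl carbon). Morpholin-4-yl enters on a carbonyl carbon whose other neighbour is an amide-type nitrogen. The closest measured change at this carbon is unreadable: a step that the limit leaves unreadable from compound 2 to compound 3. For the measured compounds named here, the expectation therefore rests on the only readable step, a 1.7-fold lower number from compound 1 to compound 3 (0.24 log units; within the scatter), where replacing a whole side group left the number within the scatter. As far as these compounds go, no step beyond the scatter is expected, though the direction stays open. The estimated step is a 1.5-fold higher number from compound 3 to compound 4 (0.16 log units; within the scatter). For compound 4 the expected value in this assay is 80 nM, with an estimated range of 30 nM to 220 nM.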

Compound 4, half-maximal inhibitory concentration: 660 nM
Compound 4: middle estimate off by 8.3-fold (0.92 log units), on the low side, outside the stated range (above it).
By their numbers in this assay, from the lowest: compounds 3 and 1 (each within the scatter of the next); then compound 4.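

In this assay, among the compounds shown here, the group on the carbonyl carbon now clearly matters: a 12-fold higher number from compound 3 to compound 4 (1.08 log units; beyond the scatter), the first readable step at this carbon and one beyond the scatter. Morpholin-4-yl also separates compound 4 from the dimethylamino compound, a 6.9-fold higher number from compound 1 to compound 4 (0.84 log units; beyond the scatter), so compounds 1 and 3 stay within the scatter of each other despite their different side groups, while compound 4 does not join them. Compound 2 carries a limit, not a number, so its step gives only a bound, an at least 6.6-fold higher number from compound 2 to compound 4 (0.81 log units; beyond the scatter), and the steps from compound 1 to compound 2 and from compound 2 to compound 3 cannot be read: the limit of < 100 nM in this assay, at which 1 of the 4 values shown sits.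

This change swaps the ring and loses the hydrogen-bond donor counted on the leaving group in one move, and the compounds shown cannot separate the two. Piperidin-1-yl or ethylamino on the same carbonyl carbon would test whether the higher number follows the ring oxygen of morpholin-4-yl, the ring itself or the missing donor.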